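The source may report more compounds than this note shows. Statements on the series, on what has been measured and on what is new or still open speak of the compounds shown alone.

Among the compounds with values here, compound 2, `C/C(=N\NC(=O)COc1cccc2ccccc12)c1ccc(Br)cc1`, has the lowest of the two numbers measured so far in an ADME assay on HEL cells (Homo sapiens) for cytotoxicity (a higher number here means that more compound is tolerated, a lower number that less compound is tolerated), where compound 2 gives 20 ug/mL. Within the data shown here, its only neighbour is compound 1, `C/C(=N\NC(=O)COc1cccc2ccccc12)c1ccc([N+](=O)[O-])cc1`, which in this assay gives 100 ug/mL; the step of a 5.0-fold lower number from compound 1 to compound 2 (0.70 log units; beyond the scatter) is the one measured step and is beyond the scatter. Compound 3, `C/C(=N\NC(=O)COc1cccc2ccccc12)c1ccc(O)cc1`, differs from compound 2 by hydroxy in place of bromo on an aromatic carbon. Among the measured compounds shown here, no measured step shows a hydroxy entering or a bromo leaving, so the single step from compound 1 to compound 2 bears on this change only indirectly, by showing that a change at this aromatic carbon can move the number by a modest amount. Compound 3 is therefore expected to lie between the two measured values, with a step of a 2.5-fold higher number from compound 2 to compound 3 (0.40 log units; beyond the scatter) that is uncertain in size. The estimate for compound 3 is 50 ug/mL, with a range from 20 ug/mL to 100 ug/mL.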

Compound 3, minimum cytotoxic concentration in the HEL assay: 20 ug/mL
Estimate against measurement, compound 3: 2.5-fold (0.40 log units) above, within the range that was stated.
By their numbers in the HEL assay, from the lowest: compounds 2 and 3 (each within the scatter of the next); then compound 1.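

In the HEL assay the exchange of bromo for hydroxy at this aromatic carbon shows no change at the digits printed from compound 2 to compound 3 (within the scatter), while the other new step reads a 5.0-fold lower number from compound 1 to compound 3 (0.70 log units; beyond the scatter). Nitro thus stands apart from both bromo and hydroxy here, and the two groups that leave and enter in this change, with their different counts of hydrogen-bond donors and acceptors, give numbers within the scatter of each other. In a physicochemical assay for lipophilicity, measured as octanol-water partition (a lower number here means a more polar compound, a higher number a more lipophilic compound), compound 2 gives 3.61 and compound 3 gives 4.44, so the same change that leaves the cytotoxicity read-out in place still moves the partition coefficient, a number 0.83 log units higher from compound 2 to compound 3 (beyond the scatter).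

Going by these compounds, what sets compound 1 apart stays open, since three groups at one position cannot tell whether its number belongs to nitro alone. An amine or a carboxylic acid at this place could fall with either level.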